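From an arylamino group to piperidin-1-yl on the shared core

The source may hold more compounds than are shown below. What is called first, only, known or untested is meant among the compounds shown, and "the series" means these compounds.

Measured in a functional assay on ECa-109 cells for inhibition, with ECa-109 cell line (Homo sapiens) as the target, read by sulforhodamine B assay; on this read-out higher numbers stand for weaker inhibition and lower numbers for stronger inhibition:
- Compound 1 `O=C1C=C(Nc2cccc(F)c2)C(=O)c2c1nc1n2[C@H]2OC[C@@H](O)[C@H]2OC1`: 7030 nM
- Compound 2 `O=C1C=C(NC2CCCC2)C(=O)c2c1nc1n2[C@H]2OC[C@@H](O)[C@H]2OC1`: > 16000 nM, which is a limit of the assay
- Compound 3 `O=C1C=C(Nc2ccc(Br)cc2)C(=O)c2c1nc1n2[C@H]2OC[C@@H](O)[C@H]2OC1`: 2850 nM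

Compound 3 has the lowest number in this assay, and the nearest value is that of compound 1, with the step being a 2.5-fold lower number from compound 1 to compound 3 (0.39 log units; beyond the scatter). Compound 4 `O=C1C=C(N2CCCCC2)C(=O)c2c1nc1n2[C@H]2OC[C@@H](O)[C@H]2OC1` carries piperidin-1-yl in place of (4-bromophenyl)amino on a double-bonded ring carbon. Within the data shown here, none of the measured compounds has this group or lacks the amine hydrogen. The closest guide is compound 2, whose cyclopentyl is also a non-aromatic ring, and it shows an at least 5.6-fold lower number from compound 2 to compound 3 (0.74 log units; beyond the scatter). The change from the aromatic 3-fluorophenyl of compound 1 to cyclopentyl points the same way, at an at least 2.2-fold higher number from compound 1 to compound 2 (0.35 log units; beyond the scatter). A rise of similar size, beyond the scatter, is therefore expected on losing the aromatic ring of compound 3. The expected change is a 4.9-fold higher number from compound 3 to compound 4 (0.69 log units; beyond the scatter). For compound 4 the estimate is 14000 nM, with an expected range of 6000 nM to 35000 nM.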

Compound 4, half-maximal inhibitory concentration: > 8000 nM
Compound 4 gave a limit, no number (the forecaster's own chance of this, stated with the estimate: 45%); the middle value does not contradict the limit.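

In this assay compound 4 gives only a limit, not a number: the limit of > 8000 nM in this assay, at which 1 of the 4 values shown sits.

Even so, this first replacement that removes both the aromatic ring and the amine hydrogen gives an at least 2.8-fold higher number from compound 3 to compound 4 (0.44 log units; beyond the scatter), so piperidin-1-yl on this double-bonded ring carbon does not hold the level of the (4-bromophenyl)amino group. Against the (3-fluorophenyl)amino group the result separates nothing, with an at least 1.1-fold higher number from compound 1 to compound 4 (0.05 log units; that floor lies within the scatter), and the step between compound 2 and compound 4 cannot be read, as both values are limits.

The compounds shown leave open whether the rise goes with the loss of the aromatic ring or of the amine hydrogen, as compound 4 lacks both. They also leave open how a (4-bromophenyl)(methyl)amino group, which keeps the aromatic ring without that hydrogen, or a morpholin-4-yl group would read in this assay.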